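Working notes: cyano in place of hydroxymethyl on the shared core

The source may hold more compounds than are shown below. What is called first, only, known or untested is meant among the compounds shown, and "the series" means these compounds.

Measured so far, all in a functional assay on the whole organism (strain Wistar albino) for inhibition, with Rattus norvegicus as the target, read by paw edema, with a stated time of 4 h, at a dose of 100 mg/kg by the oral route; on this read-out lower numbers stand for less inhibition and higher numbers for more inhibition at the one dose given (going by the name of the read-out):
compound 1 `Cc1ccc2c(Cc3nn4cc(-c5ccc(Cl)cc5)nc4s3)coc2c1`: 55.9%
compound 2 `Cc1ccc2c(Cc3nn4c(CO)c(-c5ccc(Cl)cc5)nc4s3)coc2c1`: 54.3%
compound 3 `Cc1ccc2c(Cc3nn4c(CO)c(-c5ccc(Br)cc5)nc4s3)coc2c1`: 44.9%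

Compound 2 sits within the scatter of both of its neighbours: the step of a number 1.6 percentage points lower from compound 1 to compound 2 (within the scatter) and the step of a number 9.4 percentage points lower from compound 2 to compound 3 (within the scatter) are each within the scatter, so the three numbers cannot be ordered against each other.

Compound 4 `Cc1ccc2c(Cc3nn4c(C#N)c(-c5ccc(Cl)cc5)nc4s3)coc2c1` is not yet measured in this assay. It differs from compound 2 in one place: cyano in place of hydroxymethyl on an aromatic carbon.

Going by the values given here, the step that bears on this change is the one from compound 1 to compound 2, where a hydroxymethyl group entered at the same aromatic carbon and the number moved by a number 1.6 percentage points lower from compound 1 to compound 2 (within the scatter), within the scatter. Among the compounds with values here, no measured pair shows a cyano group, so the direction of that exchange is not known here. Because a number 1.6 percentage points lower from compound 1 to compound 2 (within the scatter) was within the scatter, the expectation for compound 4 is a step of a number 0.3 percentage points lower from compound 2 to compound 4 (within the scatter), that is, none beyond the scatter. Compound 4 is therefore estimated at 54%, in the range 44% to 64%.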

Compound 4, a percentage reported as inhibition, in the whole organism at one dose (the size of the read-out at that dose, not a potency): 51.2%
Estimate against measurement, compound 4: 2.8 percentage points above; low and high end bracket the measured number.
By their numbers in this assay, from the lowest: compounds 3, 4, 2 and 1 (each within the scatter of the next, the first and the last beyond it).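

In this assay, the aromatic carbon next to the ring atom that bears a 4-chlorophenyl group now carries hydrogen, hydroxymethyl or cyano, and none of the three separates from the others: the exchange gives a number 3.1 percentage points lower from compound 2 to compound 4 (within the scatter), and cyano set against hydrogen gives a number 4.7 percentage points lower from compound 1 to compound 4 (within the scatter). Hydroxymethyl counts one hydrogen-bond donor and cyano none, and this difference goes with no step beyond the scatter, so a donor at this carbon is not shown to matter for this read-out at the one dose given. No measurement here bears on why the numbers lie so close.

Going by these compounds, it remains open whether an aminomethyl group, a carboxylic acid or a longer chain such as hydroxyethyl at this carbon would stay within the same range. On these data alone, it is also open whether cyano would give a similar number alongside the bromo group of compound 3.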